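The source may hold more compounds than are shown below. What is called first, only, known or untested is meant among the compounds shown, and "the series" means these compounds.

Compound 1 `COc1cc(OC)c2c(=O)cc(/C=C/c3ccncc3)oc2c1` was tested in a functional assay on PC-3 cells (Homo sapiens) for antiproliferative activity, read by MTT assay, with a stated time of 12 h; a lower number here means a stronger inhibitor, a higher number a weaker inhibitor. In this assay compound 1 gives only a limit, > 40000 nM, and not a number. Compound 2 `COc1ccc2c(=O)cc(/C=C/c3ccc(OC(F)(F)F)cc3)oc2c1` is the other measured structure. In this assay compound 2 likewise reaches only a limit, > 40000 nM. Compound 1 thus stands where everything measured stands, at the limit of > 40000 nM in this assay, at which 2 of the 2 values shown sit. Compound 3 `COc1cc(OC)c2c(=O)cc(/C=C/c3ccccc3)oc2c1` differs from compound 1 by phenyl in place of pyridin-4-yl on a double-bonded chain carbon bound to a double-bonded chain carbon. Among the compounds with values here, with no measured step to draw on, no change beyond the scatter is expected in this assay. Compound 3 is therefore expected to give about 40000 nM, between 15000 nM and 100000 nM. The step of a number no higher from compound 1 to compound 3 (the limit leaves the size open) is expected to be nil.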

Compound 3, half-maximal inhibitory concentration: > 40000 nM
Compound 3 gave a limit, no number; the forecaster's own chance of this, stated with the estimate: 70%; the middle value sits exactly at the limit.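

Compound 3, like compound 1, gives only a limit in this assay, so no step can be read between them: the limit of > 40000 nM in this assay, at which 3 of the 3 values shown sit.

What the compounds shown leave open is whether any replacement on the shared core would give a measurable number in this assay.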